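The source may report more compounds than this note shows. Statements on the series, on what has been measured and on what is new or still open speak of the compounds shown alone.

Measured so far:
Compound 1, `O=C(Nc1cccc(-n2cc(-c3ccncc3)c(-c3cc(O)cc(Cl)c3)n2)c1)Nc1ccc(Cl)c(Cl)c1`: 13.2%
Compound 2, `COc1cc(Cl)cc(-c2nn(-c3cccc(NC(=O)Nc4ccc(Cl)c(C(F)(F)F)c4)c3)cc2-c2ccncc2)c1`: 12%

In a functional assay on SK-OV-3 cells (Homo sapiens) for inhibition, read by sulforhodamine B assay, with a stated time of 48 h, tested at 10 uM (on this read-out lower numbers stand for a stronger effect and higher numbers for a weaker effect at the one concentration tested), compound 2 gives the lowest of the two numbers. Its nearest neighbour is compound 1, whose number is higher by an amount that lies within the scatter of repeated measurements, so the two compounds cannot be told apart on this read-out. The account now follows the step from compound 2 to compound 3, `COc1cc(Cl)cc(-c2nn(-c3cccc(NC(=O)Nc4ccc(Cl)c(Cl)c4)c3)cc2-c2ccncc2)c1`, which has not yet been measured. The change is chloro in place of trifluoromethyl on an aromatic carbon. Going by the values given here, no pair of measured compounds shows this exact change, so its size is unknown here. Given that compound 1 carries the same group that enters and gives 13.2%, the step from compound 2 to compound 3 is expected to be small, a number 2 percentage points higher from compound 2 to compound 3 (within the scatter), and not beyond the scatter. Compound 3 is therefore estimated at 14%, in a range from 6% to 25%.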

Compound 3, a percentage reported as activity, at one concentration (the size of the read-out at that concentration, not a potency): 14.2%
Beside the measured number, compound 3's estimate is 0.2 percentage points below it; the measured number falls inside the stated range.
By their numbers in this assay, from the lowest: compounds 2, 1 and 3 (each within the scatter of the next).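

In this assay, chloro in place of trifluoromethyl on an aromatic carbon, ortho to a chloro group, gives a number 2.2 percentage points higher from compound 2 to compound 3 (within the scatter), so the two groups cannot be told apart at this position. Going by these compounds alone, the same compound also gives the first reading at the oxygen on the aromatic ring, where methyl in place of hydrogen gives a number 1 percentage points higher from compound 1 to compound 3 (within the scatter), and there too the read-out does not separate the two compounds. No supporting measurement is available to explain either result.

On these data alone, it remains open whether a quite different group at the first position, such as an amine or a carboxylic acid, would give a step beyond the scatter. As far as these compounds go, it is equally open whether a longer chain on the oxygen would do so, or whether either step would hold with another group on the far ring.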